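Notes on the step from compound 1 to compound 4

This account rests on a few compounds, and the source may have more. Where it says the series, first, only, none or still open, it means among the compounds named here.

compound 1 `CCC[C@@H](CCO)Nc1nc(N)nc(C)c1Cc1ccc(CN(C)CC(N)=O)cc1OC`: > 10000 nM
compound 2 `CCC[C@@H](CO)Nc1nc(N)nc(C)c1Cc1ccc(CNC)cc1OC`: 2140 nM
compound 3 `CCC[C@@H](CO)Nc1nc(N)nc(C)c1Cc1ccc(CN(C)C)cc1OC`: 490 nM

In an assay on HEK293 cells for agonist activity at Toll-like receptor 8 (Homo sapiens) (on this read-out lower numbers stand for an effect already at smaller amounts and higher numbers for an effect only at larger amounts of compound), compound 1 gives only a limit, > 10000 nM, which is the limit of > 10000 nM in this assay, at which 1 of the 3 values shown sits. Compound 2 gives 2140 nM. Going by the values given here, compound 3 gives 490 nM, and the one measured step is a 4.4-fold lower number from compound 2 to compound 3 (0.64 log units; beyond the scatter). Compound 4 `CCC[C@@H](CCO)Nc1nc(N)nc(C)c1Cc1ccc(CNCCC(N)=O)cc1OC` differs from compound 1 by (2-carbamoylethyl)amino in place of (carbamoylmethyl)(methyl)amino on a saturated chain carbon bound to an aromatic carbon. Among the compounds with values here, this runs the measured methyl-for-hydrogen step backwards, so a move toward higher numbers is the expectation, though the start is itself only a limit and the chain lengthening has no measured counterpart here. The expected step is a step that the limit leaves unreadable from compound 1 to compound 4. Compound 4 is therefore estimated at 25000 nM, in the range 8000 nM to 80000 nM.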

Compound 4, half-maximal effective concentration: > 10000 nM
Compound 4 ended at the assay's limit (the forecaster's own chance of this, stated with the estimate: 85%); the middle value lies beyond the limit too.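

Going by these compounds alone, compound 1 and compound 4 both end at a limit, so no step between them can be read: the limit of > 10000 nM in this assay, at which 2 of the 4 values shown sit. The compounds shown leave open whether (2-carbamoylethyl)amino in place of (carbamoylmethyl)(methyl)amino changes the read-out at all.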